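The source may hold more compounds than are shown below. What is called first, only, known or untested is meant among the compounds shown, and "the series" means these compounds.

Among the compounds with values here, compound 3 `CCCC(=O)Nc1ccc(S(=O)(=O)Oc2ccccc2I)cc1` is one of three compounds measured in a functional assay on HT-1080 cells (Homo sapiens) for antiproliferative activity, read by sulforhodamine B assay, with a stated time of 48 h; a higher number here means a weaker inhibitor, a lower number a stronger inhibitor. Compound 3 gives 2000 nM, the second highest of the three numbers. Its nearest neighbour is compound 2 `CCCC(=O)Nc1ccc(S(=O)(=O)Oc2ccccc2C(C)C)cc1`, which gives 950 nM; between them lies a 2.1-fold higher number from compound 2 to compound 3 (0.32 log units; beyond the scatter). Furthest away is compound 1 `CCCC(=O)Nc1cccc(S(=O)(=O)Oc2ccccc2C(C)C)c1`, which gives 15000 nM. Compound 4 `O=C(NCC1CCCC1)Nc1ccc(S(=O)(=O)Oc2ccccc2I)cc1` has not yet been measured. It differs from compound 3 in a single place: (cyclopentylmethyl)amino in place of propyl on a carbonyl carbon. Within the data shown here, no measured step bears on this part of the molecule. Among the measured compounds shown here, the only recorded step, from compound 2 to compound 3, swaps iodo for isopropyl on an aromatic carbon, and the two values of compound 1 and compound 2 differ without any single-point step linking them. The group attached to the carbonyl carbon is the same in all three measured compounds, so the data give no direct guide for this change in this assay. Compound 4 is therefore expected to sit close to compound 3, with the step of no change at the digits printed from compound 3 to compound 4 (within the scatter) estimated to stay within the scatter. Compound 4 is estimated at 2000 nM, with a range from 600 nM to 7000 nM.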

Compound 4, half-maximal inhibitory concentration: 6100 nM
Estimate against measurement, compound 4: 3.1-fold (0.48 log units) below, and the stated range covers the measured number.
By their numbers in this assay, from the lowest: compound 2; then compound 3; then compound 4; then compound 1.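

The carbonyl carbon now has its first reading in this assay: the group there can be changed with a measurable cost, shown by a 3.1-fold higher number from compound 3 to compound 4 (0.48 log units; beyond the scatter), a modest step beyond the scatter. The change brings in a nitrogen with a hydrogen-bond donor, a five-membered non-aromatic ring and a larger group all at once, so this single step cannot separate their contributions. Nothing available here explains why the number rises.

Still open, as far as these compounds go, is whether butylamino, with a nitrogen but no ring, or cyclopentylmethyl, with the ring but no nitrogen, would stay closer to compound 3. Also open, from the compounds shown here alone, is whether the same replacement would give a similar step with isopropyl in place of iodo, as in compound 2.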